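Trimming a benzoyloxy group from a triazole side chain

A few compounds are considered here, and "the series" means these few. Any claim that something is new, unique, unknown or untested is made for them only; others in the source may bear on it.

Measured compounds:
compound 1 `CCCCNC(=O)OCC(O)Cn1cc(CN2CCCC(C(=O)OCC)C2)nn1`: 24%
compound 2 `CCOC(=O)C1CCCN(Cc2cn(C3CCCCC3O)nn2)C1`: 16%
compound 3 `CCOC(=O)C1CCCN(Cc2cn(CC(O)COC(=O)c3ccccc3)nn2)C1`: 6%

In an assay on nucleic acid for inhibition of Nucleic Acid, read by fluorescence, tested at 100 uM (a higher number here means more inhibition at the concentration tested (going by the name of the read-out), a lower number less inhibition), compound 3 gives the lowest of the three numbers. Its gap to compound 2 lies within the scatter, while the step of a number 18 percentage points lower from compound 1 to compound 3 (beyond the scatter) lies beyond it.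

Compound 4 `CCCCC(O)Cn1cc(CN2CCCC(C(=O)OCC)C2)nn1` is not yet measured. It differs from compound 3 by propyl in place of benzoyloxy on a saturated chain carbon, two bonds along the chain from an oxygen on a saturated carbon.

Among the measured compounds shown here, no measured step covers this exact change. For the measured compounds named here, the only step seen, a number 18 percentage points lower from compound 1 to compound 3 (beyond the scatter), concerns a different position and is modest. Compound 2, which also carries a plain hydroxyl-bearing ring without an ester, sits within the scatter of compound 3. A small rise is therefore expected, a number 9 percentage points higher from compound 3 to compound 4 (within the scatter), but not a large one.

For compound 4 an estimate of 15% is expected, within 4% to 28%.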

Compound 4, a percentage reported as inhibition, at one concentration (the size of the read-out at that concentration, not a potency): 53%
For compound 4 the middle estimate is 38 percentage points below the measured one; measured number above the stated range.
By their numbers in this assay, from the lowest: compounds 3, 2 and 1 (each within the scatter of the next, the first and the last beyond it); then compound 4.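

In this assay, propyl in place of benzoyloxy gives a number 47 percentage points higher from compound 3 to compound 4 (beyond the scatter), and propyl in place of (butylcarbamoyl)oxy at the same place gives a number 29 percentage points higher from compound 1 to compound 4 (beyond the scatter), so this place on the side chain responds strongly to what is attached there. The change of 2-hydroxycyclohexyl to 2-hydroxyhexyl on the aromatic nitrogen gives a number 37 percentage points higher from compound 2 to compound 4 (beyond the scatter), so the open chain also stands well clear of the ring. Nothing measured here explains these large steps. As far as these compounds go, whether a longer chain or an amine at this place would raise the number further stays open, as does whether the hydroxyl on the chain is needed.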